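The source may hold more compounds than are shown below. What is called first, only, known or untested is meant among the compounds shown, and "the series" means these compounds.

Measured compounds:
compound 1 `COCCNC(=O)c1cc2cccc(OC)c2oc1=O`: 45%
compound 2 `COCCNC(=O)c1cc2cccc(OC)c2oc1=N`: > 70%
compound 3 `COc1cccc2cc(C(=O)NCCCCCO)c(=N)oc12`: 44%

In an assay on CHO cells for displacement of a labelled ligand from adenosine receptor A1 (Homo sapiens), read by scintillation counting, with a stated time of 60 min, tested at 10 uM (a lower number here means less inhibition, a higher number more inhibition at the concentration tested (going by the name of the read-out)), compound 1 gives 45%. Compound 2 is reported only at a limit of the assay, > 70%, not as a number; this is the limit of > 70% in this assay, at which 1 of the 3 values shown sits. Compound 3 gives 44%. Compound 3 thus stands lowest of the two numbers, and compound 1 sits within the scatter of it. Within the data shown here, the one measured step that touches this side chain is a number at least 26 percentage points lower from compound 2 to compound 3 (beyond the scatter), so exchanging the methoxy-terminated chain for the longer hydroxy-terminated one lowers inhibition by at least a modest amount, with the true size unknown above that floor.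

Compound 4 `COc1cccc2cc(C(=O)NCCO)c(=N)oc12` differs from compound 3 by hydroxy in place of 3-hydroxypropyl on a saturated chain carbon, two bonds along the chain from an amide-type nitrogen. The chain is cut back to the length of compound 2 while the hydroxy terminus of compound 3 is kept, so the outcome is expected to lie between the two measured results. An upward step is expected, a number 14 percentage points higher from compound 3 to compound 4 (beyond the scatter). Compound 4 is estimated at 58%, with a range from 40% to 78%.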

Compound 4, a percentage reported as inhibition, at one concentration (the size of the read-out at that concentration, not a potency): 47%
Estimate against measurement, compound 4: 11 percentage points above; the range from low to high includes it.
By their numbers in this assay, from the lowest: compounds 3, 1 and 4 (each within the scatter of the next). At a limit, above all of these: compound 2.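

In this assay, the 5-hydroxypentyl and 2-hydroxyethyl side chains read alike, a number 3 percentage points higher from compound 3 to compound 4 (within the scatter), so among these hydroxy-terminated amides chain length does not separate the compounds. At the length of the 2-hydroxyethyl chain, hydrogen in place of methyl on the chain-end oxygen gives a number at least 23 percentage points lower from compound 2 to compound 4 (beyond the scatter), which places the loss of inhibition seen earlier with this change and not with the longer chain. Compound 2 stands at a limit, so this step has only a floor and no measured size: the limit of > 70% in this assay, at which 1 of the 4 values shown sits.

As far as these compounds go, how far the true value of compound 2 lies beyond that limit remains open. From the compounds shown here alone, it is also open whether a longer chain ending in methoxy keeps the higher inhibition, and how a terminal amine or carboxylic acid on this chain would read.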